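The source may hold more compounds than are shown below. What is called first, only, known or untested is meant among the compounds shown, and "the series" means these compounds.

Of the compounds shown here, two that share one core have been tested for how strongly they harm cells in an ADME assay on Vero cells (Chlorocebus sabaeus) for cytotoxicity, read by MTT assay, with a stated time of 48 h; a higher number here means a weaker inhibitor, a lower number a stronger inhibitor. Compound 1 `O=c1cc(Nc2ccccc2)sc2c([N+](=O)[O-])cc(C(F)(F)F)cc12` gives > 64 ug/mL in this assay, and this is a limit of the assay rather than a measured number. Compound 2 `C[C@H]1COC2(CCN(c3nc(=O)c4cc(C(F)(F)F)cc([N+](=O)[O-])c4s3)CC2)O1`, which carries a different group on the shared core, gives > 64 ug/mL in this assay, again a limit and not a number. For the measured compounds named here, compound 1 therefore stands at the limit of > 64 ug/mL in this assay, at which 2 of the 2 values shown sit, and no step between two measured compounds is known, so the size of any change has to be judged from the structures alone.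

Compound 3 `O=c1cc(NCc2ccc(F)cc2)sc2c([N+](=O)[O-])cc(C(F)(F)F)cc12` differs from compound 1 in one place: 4-fluorobenzyl in place of phenyl on a nitrogen on an aromatic ring. Going by the values given here, nothing among the measured compounds points to a step in either direction here, so the step of a number no higher from compound 1 to compound 3 (the limit leaves the size open) is expected to be none beyond the scatter, because compound 1 already sits at the limit of > 64 ug/mL in this assay, at which 2 of the 2 values shown sit. Compound 3 is thus expected to give about 64 ug/mL in this assay, somewhere between 30 ug/mL and 150 ug/mL, most likely again reported only as a limit.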

Compound 3, half-maximal inhibitory concentration: > 64 ug/mL
Compound 3 ended at the assay's limit; the forecaster's own chance of this, stated with the estimate: 75%; the middle value lies on the limit itself.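

For the compounds shown here, compound 1 and compound 3 are both reported only as a limit in this assay, not as a number, so no step between them can be read: the limit of > 64 ug/mL in this assay, at which 3 of the 3 values shown sit. The compounds shown leave open how much any of them harms these cells, and whether 4-fluorobenzyl in place of phenyl changes that at all.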